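Moving a chlorine on the nitrogen-bound aryl group

A few compounds are considered here, and "the series" means these few. Any claim that something is new, unique, unknown or untested is made for them only; others in the source may bear on it.

In an assay on microsomes from intestine for inhibition of acyl-CoA:cholesterol acyltransferase (Oryctolagus cuniculus) (on this read-out lower numbers stand for stronger inhibition and higher numbers for weaker inhibition), compound 1 `Cc1cccc(C)c1N1N=C(CC(c2ccccc2)c2ccccc2)CC1=O` gives 50800 nM. Compound 3 `CCCCCCCCCCC1=NN(c2c(C)cccc2C)C(=O)C1`, which carries a saturated chain on the shared core, gives 5000 nM in this assay. Compound 2 `CCCCCCCC/C=C\CCCCCCCC1=NN(c2c(Cl)cccc2Cl)C(=O)C1`, bearing the long unsaturated chain and a 2,6-dichlorophenyl group on the ring nitrogen, gives 22900 nM in this assay. Among the three numbers compound 2 stands second highest: compound 1 lies above it by a margin beyond the usual scatter, and compound 3 lies below it by a wider margin, also beyond the scatter.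

Compound 4 `CCCCCCCC/C=C\CCCCCCCC1=NN(c2ccc(Cl)cc2Cl)C(=O)C1` has the same atoms as compound 2, joined differently: 2,4-dichlorophenyl in place of 2,6-dichlorophenyl on an amide-type nitrogen in a ring. Going by the values given here, no pair of measured compounds differs only in this way, so nothing measured shows how this rearrangement plays out in this assay. With the chain and the core unchanged, only a modest step is expected, if any beyond the scatter, and the direction is uncertain.

Compound 4 is expected to give 15000 nM in this assay, within a range from 5000 nM to 45000 nM. The step from compound 2 to compound 4 is accordingly estimated at a 1.5-fold lower number from compound 2 to compound 4 (0.18 log units; within the scatter), a small move toward stronger inhibition that need not exceed the scatter.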

Compound 4, half-maximal inhibitory concentration: 9900 nM
Compound 4: the middle estimate sits 1.5-fold (0.18 log units) above what was measured; the measured number falls inside the stated range.
By their numbers in this assay, from the lowest: compounds 3 and 4 (each within the scatter of the next); then compound 2; then compound 1.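

In this assay, going by these compounds alone, moving a chlorine on the aryl group is the first change in this set that can be read on its own: it gives a 2.3-fold lower number from compound 2 to compound 4 (0.36 log units; beyond the scatter) and this modest step lies beyond the scatter. With the long unsaturated chain and the shared core held fixed, the result shows that the read-out responds to the arrangement of the chlorines on the aryl group at this amide-type nitrogen, even though the leaving and entering groups have the same heavy-atom, ring and hydrogen-bond counts. No measurement at hand accounts for the lower number with 2,4-dichlorophenyl.

The compounds shown leave open whether the same rearrangement would give a similar step on the saturated chain of compound 3 or on the diphenyl-bearing side chain of compound 1. They also leave open how this position would respond to a phenyl group with a single chlorine, or to one with methoxy or trifluoromethyl groups in place of the chlorines.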